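Hydroxycarbamoyl in place of 2H-tetrazol-5-yl on a shared core

The source may report more compounds than this note shows. Statements on the series, on what has been measured and on what is new or still open speak of the compounds shown alone.

Compound 1 `CC[C@H](C)[C@H](NC(=O)c1cccc(Cn2ccnc2)c1)C(=O)Nc1nccs1`, compound 2 `CC[C@H](C)[C@H](NC(=O)c1cccc(Cn2ccnc2)c1)c1nn[nH]n1`, compound 3 `CCCCCS(=O)(=O)NNC(=O)[C@@H](NC(=O)c1cccc(Cn2ccnc2)c1)[C@@H](C)CC` and compound 4 `CC[C@H](C)[C@H](NC(=O)c1cccc(Cn2ccnc2)c1)C(=O)NO` are built on one shared core and differ only in the group carried on a saturated chain carbon bound to an amide-type nitrogen and a saturated chain carbon.

In an assay on HEK293 cells for displacement of a labelled ligand from Type-2 angiotensin II receptor (Homo sapiens), tested at 1 uM (a higher number here means a stronger effect of the compound at the concentration tested, a lower number a weaker effect), compound 1 gives 4%. In this assay compound 2 is reported as "not active" (no number reported), so no single number marks where it stands. In this assay compound 3 is reported as "not determined" (no result reported), a further entry without a number. Thus, among the measured compounds, only compound 1 offers a figure, and it is a small one.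

The change from compound 2 to compound 4 is hydroxycarbamoyl in place of 2H-tetrazol-5-yl on a saturated chain carbon bound to an amide-type nitrogen and a saturated chain carbon.

Among the measured compounds shown here, no step between two measured compounds is available to judge what such a change does here. Given that, the expected move in this assay on going from compound 2 to compound 4 is none beyond the usual scatter, with a small number in the same low region as the rest of the set. For compound 4 the estimate in this assay is 5%, with an expected range from 0% to 20%. This expectation rests on compound 1 giving 4% and on compound 2 being reported as "not active" (no number reported).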

Compound 4, a percentage reported as inhibition, at one concentration (the size of the read-out at that concentration, not a potency): "not active" (no number reported)
The entry for compound 4 holds no number; there is nothing to compare the estimate with.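

In this assay compound 2 and compound 4 are both reported as "not active", with no number, so no step can be read between them. No measured evidence bears on this result. The compounds shown leave open whether hydroxycarbamoyl and 2H-tetrazol-5-yl differ at all in their effect on the shared core.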